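Furan replacement on the amine-bound chain of compound 2

A few compounds are considered here, and "the series" means these few. Any claim that something is new, unique, unknown or untested is made for them only; others in the source may bear on it.

Compound 2 `Fc1ccc(-c2ccc3c(NCCCNCc4ccco4)ccnc3c2)cc1` gives 9.47 in a physicochemical assay for acid dissociation, level with compound 3 `c1ccc(CCc2ccc3c(NCCCNCc4ccco4)ccnc3c2)cc1` at 9.47, and its furthest partner is compound 1 `COc1ccccc1Oc1ccc2c(NCCCNCc3ccco3)ccnc2c1` at 9.28; the steps of a number 0.19 log units higher from compound 1 to compound 2 (within the scatter) and no change at the digits printed from compound 2 to compound 3 (within the scatter) both stay within the scatter. Compound 4 `COc1cccc(CNCCCNc2ccnc3cc(-c4ccc(F)cc4)ccc23)c1O` carries 2-hydroxy-3-methoxyphenyl in place of furan-2-yl on a saturated chain carbon bound to an amine nitrogen. Among the compounds with values here, no measured step touches the saturated chain carbon bound to the amine nitrogen: the steps of a number 0.19 log units higher from compound 1 to compound 2 (within the scatter), a number 0.19 log units higher from compound 1 to compound 3 (within the scatter) and no change at the digits printed from compound 2 to compound 3 (within the scatter) all sit on an aromatic carbon of the core and none moved the number beyond the scatter. With nothing bearing on this place, only a small step is expected in this assay, estimated as a number 0.13 log units higher from compound 2 to compound 4 (within the scatter). Compound 4 is therefore expected at 9.6, within 9 to 10.2.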

Compound 4, acid dissociation constant: 9.47
The estimate for compound 4 lay 0.13 log units above the measured number; measured number inside the range.
By their numbers in this assay, from the lowest: compounds 1, 2, 3 and 4 (each within the scatter of the next).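

At the saturated chain carbon bound to an amine nitrogen, this assay reads no change at the digits printed from compound 2 to compound 4 (within the scatter) on going from (furan-2-yl)methyl to 2-hydroxy-3-methoxybenzyl. This position therefore accepts a six-membered aromatic ring of carbon only in place of a five-membered aromatic ring with 1 hetero atom, with a hydrogen-bond donor added, and the read-out stays within the scatter. Nothing available accounts for this result. 

Going by these compounds, whether an amine or a carboxylic acid at this place would move the number remains open. Also open, on these data alone, is whether the same holds with phenethyl or 2-methoxyphenoxy on the core.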